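The source may hold more compounds than are shown below. What is called first, only, known or untested is meant among the compounds shown, and "the series" means these compounds.

Measured compounds:
compound 1 `COC(=O)/C=C/c1ccc2c(c1)C(=O)C(=O)N2Cc1ccc(OC)cc1`; in a functional assay on Jurkat cells (Homo sapiens) for antiproliferative activity, read by MTT assay, with a stated time of 48 h (a higher number here means a weaker inhibitor, a lower number a stronger inhibitor), compound 1 gives 30 nM.
compound 2 `CCOC(=O)/C=C/c1ccc2c(c1)C(=O)C(=O)N2Cc1ccc(OC)cc1`; in this assay compound 2 gives 30 nM.

Among the measured compounds shown here, compound 2 stands level with compound 1; the single measured step, no change at the digits printed from compound 1 to compound 2 (within the scatter), lies within the scatter and concerns only the ester chain. Compound 3 `CCOC(=O)/C=C/c1ccc2c(c1)C(=O)C(=O)N2Cc1ccc(Br)cc1` differs from compound 2 by bromo in place of methoxy on an aromatic carbon. For the measured compounds named here, no measured step touches that part of the structure, so the series gives no guide to this change. The expected step in this assay is therefore none beyond the scatter, no change at the digits printed from compound 2 to compound 3 (within the scatter), with a wide range. Compound 3 is estimated at 30 nM, between 8 nM and 120 nM.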

Compound 3, half-maximal inhibitory concentration: 70 nM
For compound 3 the middle estimate is 2.3-fold (0.37 log units) below the measured one; measured number inside the range.
By their numbers in this assay, from the lowest: compounds 1 and 2 (each within the scatter of the next); then compound 3.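

In this assay, among the compounds shown here, the change from 4-methoxybenzyl to 4-bromobenzyl gives a 2.3-fold higher number from compound 2 to compound 3 (0.37 log units; beyond the scatter) and is the first step beyond the scatter. This aromatic carbon therefore responds to substitution, whereas the ester chain step did not, though the size of the response is modest. Nothing available bears on the reason for this step.

Open, on these data alone, is how an amine or a carboxylic acid on this aromatic carbon would compare with methoxy and bromo. Also open, as far as these compounds go, is whether the same step would appear with the methyl ester of compound 1.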